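Diaryl-urea pyrazoles: swapping the terminal aryl group

The source may hold more compounds than are shown below. What is called first, only, known or untested is meant among the compounds shown, and "the series" means these compounds.

Compound 1 `COc1cc(Cl)cc(-c2nn(-c3cccc(NC(=O)Nc4ccc(Cl)c(C(F)(F)F)c4)c3)cc2-c2ccncc2)c1`: 99%
Compound 2 `COc1cc(Cl)cc(-c2nn(-c3cccc(NC(=O)Nc4cc(C(F)(F)F)cc(C(F)(F)F)c4)c3)cc2-c2ccncc2)c1`: 93%
Compound 3 `COc1cc(Cl)cc(-c2nn(-c3cccc(NC(=O)Nc4ccc(Cl)c(Cl)c4)c3)cc2-c2ccncc2)c1`: 93%

In a functional assay on OVCAR-4 cells (Homo sapiens) for inhibition, read by sulforhodamine B assay, with a stated time of 48 h, tested at 0.01 uM (a lower number here means a stronger effect, a higher number a weaker effect of the compound at the concentration tested), compound 3 gives 93%, level with compound 2 at the digits shown and together with it the lowest of the three numbers, while compound 1 sits a step higher, a gap that stays within the scatter. Among the compounds with values here, the one measured step that touches the same terminal aryl group runs a number 6 percentage points lower from compound 1 to compound 3 (within the scatter), chloro in place of trifluoromethyl on an aromatic carbon, and it lies within the scatter.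

Compound 4 `COc1cc(Cl)cc(-c2nn(-c3cccc(NC(=O)Nc4cccc(C(F)(F)F)c4)c3)cc2-c2ccncc2)c1` differs from compound 3 by 3-(trifluoromethyl)phenyl in place of 3,4-dichlorophenyl on an amide-type nitrogen. Within the data shown here, this change bears some resemblance to the step from compound 1 to compound 3, which was within the scatter, and no other measured pair speaks to it. All three measured compounds cluster closely in this assay, so no step beyond the scatter is expected here. The estimate for compound 4 in this assay is therefore 95%, between 85% and 104%, which is expected to mean a step of a number 2 percentage points higher from compound 3 to compound 4 (within the scatter).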

Compound 4, a percentage reported as activity, at one concentration (the size of the read-out at that concentration, not a potency): 93%
For compound 4 the middle estimate is 2 percentage points above the measured one, and the stated range covers the measured number.
By their numbers in this assay, from the lowest: compounds 2, 3, 4 and 1 (each within the scatter of the next).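

In this assay the step of no change at the digits printed from compound 3 to compound 4 (within the scatter) replaces the 3,4-dichlorophenyl on the amide-type nitrogen with 3-(trifluoromethyl)phenyl and leaves the reading within the scatter. Stripping a substituent from the terminal ring does no more, since hydrogen in place of trifluoromethyl gives no change at the digits printed from compound 2 to compound 4 (within the scatter) and hydrogen in place of chloro gives a number 6 percentage points lower from compound 1 to compound 4 (within the scatter) with neither step leaving the scatter, so across these four compounds a single trifluoromethyl serves this position as well as the disubstituted rings do. Nothing measured here accounts for this flat response.

Still open, on these data alone, is whether the reading holds with an unsubstituted phenyl, or with a terminal ring bearing an amine or a carboxylic acid. A cyclohexyl group on the same nitrogen would show whether an aromatic ring is needed there at all.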